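A Methyl Added to a Scaffold That Shows No Toxicity

A few compounds are considered here, and "the series" means these few. Any claim that something is new, unique, unknown or untested is made for them only; others in the source may bear on it.

Compound 1 `COc1ccc(-n2c(=O)n(Cc3cc4cc(Cl)ccc4n3CCCC#N)c3cnccc32)cc1` was tested in an ADME assay on HeLa cells (Homo sapiens) for cytotoxicity, read by ATP content, with a stated time of 3 days; on this read-out lower numbers stand for higher toxicity in this test and higher numbers for lower toxicity in this test. In this assay compound 1 gives only a limit, > 50000 nM, not a number. Compound 2 `O=c1n(Cc2cc3cc(Cl)ccc3n2CCCCF)c2cnccc2n1C1CC1` shares the core and differs elsewhere. In this assay compound 2 likewise gives only a limit, > 50000 nM. Both results sit at the same edge: the limit of > 50000 nM in this assay, at which 2 of the 2 values shown sit. Compound 1 therefore stands at the limit of this assay, with no number to set it against compound 2.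

Compound 3 `COc1ccc(-n2c(=O)n(Cc3cc4cc(Cl)ccc4n3CCCC#N)c3cnccc32)c(C)c1` is not yet measured. It differs from compound 1 in one way (methyl in place of hydrogen on an aromatic carbon). Among the measured compounds shown here, no step between two measured compounds is available here to guide the expectation. With both known results at the limit, the change from compound 1 to compound 3 is expected to give no step beyond the usual scatter in this assay, a step that the limit leaves unreadable from compound 1 to compound 3. Compound 3 is accordingly estimated at 60000 nM, between 30000 nM and 150000 nM, and will most likely be reported again only as a limit.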

Compound 3, half-maximal cytotoxic concentration: > 50000 nM
Compound 3: no number, only a limit (the forecaster's own chance of this, stated with the estimate: 85%); the middle value does not contradict the limit.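

No step can be read from compound 1 to compound 3, because both give only a limit in this assay, not a number: the limit of > 50000 nM in this assay, at which 3 of the 3 values shown sit.

The compounds shown leave open whether methyl in place of hydrogen changes toxicity in this test at all, and what number any of these three compounds would give.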